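A Naphthalene Swap Tested on a Weaker Core

This account rests on a few compounds, and the source may have more. Where it says the series, first, only, none or still open, it means among the compounds named here.

Four compounds share one scaffold and differ in two parts. Compound 1 `COc1ccc(OC)c(COc2cc(NC(=O)c3ccc(I)cc3)ccc2N(C)S(C)(=O)=O)c1` is the reference. Compound 2 `COc1ccc(OC)c(COc2cc(NC(=O)c3ccc4ccccc4c3)ccc2N(C)S(C)(=O)=O)c1` carries the change (naphthalen-2-yl in place of 4-iodophenyl on a carbonyl carbon). Compound 3 `COc1ccc(OC)c(COc2cc(NC(=O)c3ccc(I)cc3)ccc2N(C)S(=O)(=O)C(F)(F)F)c1` instead carries the change (trifluoromethyl in place of methyl on a sulfonyl sulfur). Compound 4 `COc1ccc(OC)c(COc2cc(NC(=O)c3ccc4ccccc4c3)ccc2N(C)S(=O)(=O)C(F)(F)F)c1` combines both changes and has not yet been measured.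

All were tested in a functional assay on SK-BR-3 cells (Homo sapiens) for antiproliferative activity, read by MTT assay, with a stated time of 48 h; on this read-out higher numbers stand for weaker inhibition and lower numbers for stronger inhibition. Compound 1 gives 1.21 nM. Compound 2 gives 16.6 nM, and the step of a 14-fold higher number from compound 1 to compound 2 (1.14 log units; beyond the scatter) shows a clear loss of potency. Compound 3 gives 510 nM, and the step of a 420-fold higher number from compound 1 to compound 3 (2.62 log units; beyond the scatter) is much larger still, leaving compound 3 the weakest of the three measured compounds.

Compound 4 differs from compound 3 by naphthalen-2-yl in place of 4-iodophenyl on a carbonyl carbon, which is the same change seen from compound 1 to compound 2, at the same place. The cores differ by trifluoromethyl in place of methyl on a sulfonyl sulfur. The expectation for compound 4 rests on that earlier step: if the naphthalene swap costs about as much on the core of compound 3 as it did on the core of compound 1, where a 14-fold higher number from compound 1 to compound 2 (1.14 log units; beyond the scatter) was measured, then a step of roughly a 9.8-fold higher number from compound 3 to compound 4 (0.99 log units; beyond the scatter) is expected from compound 3 to compound 4. Among the compounds with values here, whether the two changes add up cannot be checked here, since only one example of the swap exists, so the range is kept wide. Compound 4 is estimated at 5000 nM in this assay, with a likely span from 1000 nM to 25000 nM.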

Compound 4, half-maximal inhibitory concentration: 200 nM
Estimate against measurement, compound 4: 25-fold (1.40 log units) above; the whole stated range lies above it.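

In this assay, the swap to naphthalen-2-yl from 4-iodophenyl on the carbonyl carbon changes direction on the trifluoromethyl core, giving a 2.6-fold lower number from compound 3 to compound 4 (0.41 log units; beyond the scatter), so the loss seen on the core of compound 1 does not carry over to this core: the same change on two cores in this assay, a 14-fold higher number (1.14 log units; beyond the scatter) from compound 1 to compound 2 and a 2.6-fold lower number (0.41 log units; beyond the scatter) from compound 3 to compound 4, 35-fold (1.54 log units) apart, beyond the scatter of two such steps. The change from methyl to trifluoromethyl on the sulfonyl sulfur raises the number on both cores, but with naphthalen-2-yl in place it gives a 12-fold higher number from compound 2 to compound 4 (1.08 log units; beyond the scatter), a much smaller rise than on the 4-iodophenyl core: the same change on two cores in this assay, a 420-fold higher number (2.62 log units; beyond the scatter) from compound 1 to compound 3 and a 12-fold higher number (1.08 log units; beyond the scatter) from compound 2 to compound 4, 35-fold (1.54 log units) apart, beyond the scatter of two such steps. Together these steps show that the two changes do not simply add up in these four compounds, but they do not show why, and a single square of compounds cannot tell whether the same behaviour would hold for other groups.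

The compounds shown leave open whether a 4-bromophenyl or 4-chlorophenyl group on the carbonyl carbon would follow the pattern of 4-iodophenyl or that of naphthalen-2-yl on each core. They also leave open how an ethyl group or a longer chain on the sulfonyl sulfur would behave alongside either of these two groups.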